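This account rests on a few compounds, and the source may have more. Where it says the series, first, only, none or still open, it means among the compounds named here.

Three amides built on one shared core have been tested in a functional assay on BGC-823 cells (Homo sapiens) for antiproliferative activity, read by MTT assay, with a stated time of 48 h; on this read-out lower numbers stand for an effect already at smaller amounts and higher numbers for an effect only at larger amounts of compound. Compound 1 `O=C(Nc1nnc(-c2ccc3c(c2)OCCO3)s1)c1ccccc1` gives 46.2 ug/mL, compound 2 `O=C(CCc1ccccc1)Nc1nnc(-c2ccc3c(c2)OCCO3)s1` gives 14.2 ug/mL, and compound 3 `O=C(Nc1nnc(-c2ccc3c(c2)OCCO3)s1)c1ccccn1` gives 35.8 ug/mL. Among these three numbers compound 3 stands second highest: the step of a 1.3-fold lower number from compound 1 to compound 3 (0.11 log units; within the scatter) lies within the scatter, while the step of a 2.5-fold higher number from compound 2 to compound 3 (0.40 log units; beyond the scatter) goes beyond it. The next compound, compound 4 `O=C(Nc1nnc(-c2ccc3c(c2)OCCO3)s1)c1ccncc1`, differs from compound 3 only in that (pyridin-4-yl in place of pyridin-2-yl on a carbonyl carbon). Among the measured compounds shown here, no measured step exchanges pyridin-2-yl for pyridin-4-yl, so the nearest guide is a 1.3-fold lower number from compound 1 to compound 3 (0.11 log units; within the scatter), an exchange of one six-membered aromatic ring for another on the same carbonyl carbon, which stayed within the scatter; the larger steps of a 3.3-fold lower number from compound 1 to compound 2 (0.51 log units; beyond the scatter) and a 2.5-fold higher number from compound 2 to compound 3 (0.40 log units; beyond the scatter) involved the phenethyl chain and were only modest. On this basis the step of a 1.0-fold lower number from compound 3 to compound 4 (0.01 log units; within the scatter) is expected to remain within the scatter. Compound 4 is therefore estimated at 35 ug/mL in this assay, with an expected range from 17 ug/mL to 70 ug/mL.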

Compound 4, half-maximal effective concentration: 41 ug/mL
The estimate for compound 4 lay 1.2-fold (0.07 log units) below the measured number, within the range that was stated.
By their numbers in this assay, from the lowest: compound 2; then compounds 3, 4 and 1 (each within the scatter of the next).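

In this assay, among the compounds shown here, the exchange of pyridin-2-yl for pyridin-4-yl on the carbonyl carbon gives a 1.1-fold higher number from compound 3 to compound 4 (0.06 log units; within the scatter), so this assay does not separate the two pyridine attachments, a comparison the earlier compounds could not offer. The pyridin-4-yl amide also stays level with the phenyl amide, with a 1.1-fold lower number from compound 1 to compound 4 (0.05 log units; within the scatter), whereas the phenethyl amide remains modestly apart, with a 2.9-fold higher number from compound 2 to compound 4 (0.46 log units; beyond the scatter); among these four compounds, only the phenethyl amide stands out. Nothing available explains these numbers.

The compounds shown leave open how pyridin-3-yl would compare at this position, and whether a pyridin-4-yl ring carried on the same chain as in phenethyl would follow compound 2. They also leave open whether an amine or a carboxylic acid on the ring would move the number.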